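The source may hold more compounds than are shown below. What is called first, only, known or untested is meant among the compounds shown, and "the series" means these compounds.

Working notes on the series. All members share one core. Compound 1 `CCCCCCCCCC/N=c1\nc(N)c2ncn(Cc3ccccc3)c2c(N)n1` gives 5150 nM in a functional assay on PC-3 cells (Homo sapiens) for antiproliferative activity, read by WST assay, with a stated time of 72 h; on this read-out higher numbers stand for weaker inhibition and lower numbers for stronger inhibition. Compound 2 `CCCCCCCC/N=c1\nc(N)c2ncn(Cc3ccc(OC)cc3)c2c(N)n1` gives 5900 nM in this assay; this is the higher of the two numbers recorded so far, but its nearest neighbour is compound 1 and the two values lie within the scatter of each other, so nothing separates compound 1 from compound 2 on this read-out.

Compound 3 `CCCCCCCC/N=c1\nc(N)c2nc[nH]c2c(N)n1` has not yet been measured. It differs from compound 2 in one place: hydrogen in place of 4-methoxybenzyl on an aromatic nitrogen. Among the compounds with values here, no measured pair in the set isolates a change of this kind, so there is no step from which its size can be read. Within the data shown here, the two measured values show only that the difference between compound 1 and compound 2 does not move the number beyond the scatter. Removing the whole group is a larger change, and a modest move toward a higher number, that is weaker inhibition, is expected as the step of a 1.9-fold higher number from compound 2 to compound 3 (0.27 log units; within the scatter), though an outcome within the scatter cannot be excluded. Compound 3 is therefore estimated at 11000 nM, with a range from 4000 nM to 30000 nM.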

Compound 3, half-maximal inhibitory concentration: "not active" (no number reported)
Compound 3: no number reported; no gap can be computed for the estimate.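

Within the data shown here, compound 3 is reported as not active, without a number, and no step from compound 2 to compound 3 can be read. No supporting data bear on this result. The compounds shown leave open how far the number moves when hydrogen replaces 4-methoxybenzyl on the aromatic nitrogen.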